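The source may hold more compounds than are shown below. What is called first, only, known or untested is meant among the compounds shown, and "the series" means these compounds.

Measured compounds:
Compound 1 `O=C1C=CC(=O)C(c2cc(-c3ccc(C(=O)N4CCC(C(F)(F)F)CC4)s3)on2)=C1` gives in a functional assay on A549 cells (Homo sapiens) for cytotoxicity, read by XTT assay, with a stated time of 72 h (a higher number here means a weaker inhibitor, a lower number a stronger inhibitor), only > 30000 nM, a limit of the assay rather than a number.
Compound 2 `COc1ccc(OC)c(-c2cc(-c3ccc(C(=O)N(C)Cc4ccc(F)cc4)s3)on2)c1` gives > 30000 nM, again a limit.
Compound 3 `CN(Cc1ccc(F)cc1)C(=O)c1ccc(-c2cc(C3=CC(=O)C=CC3=O)no2)s1` gives > 30000 nM, also a limit.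

Compound 3 thus stands at the limit of > 30000 nM in this assay, at which 3 of the 3 values shown sit; every value shown is a limit and none is a number. Compound 4 `COc1ccc(CN(C)C(=O)c2ccc(-c3cc(C4=CC(=O)C=CC4=O)no3)s2)cc1` differs from compound 3 by methoxy in place of fluoro on an aromatic carbon. The two measured steps into compound 3, a step that the two limits leave unreadable from compound 1 to compound 3 and a step that the two limits leave unreadable from compound 2 to compound 3, cannot be sized, since both ends sit at the limit. They bear on compound 4 only in showing that changes on the carbonyl carbon and on an aromatic carbon of the shared core left the limit unchanged. No step beyond the scatter is expected, so the step is estimated as a step that the limit leaves unreadable from compound 3 to compound 4. Compound 4 is expected to give 40000 nM, in the range 10000 nM to 150000 nM, most likely again only a limit.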

Compound 4, half-maximal inhibitory concentration: > 30000 nM
Compound 4 gave a limit, no number (the forecaster's own chance of this, stated with the estimate: 85%); the middle value lies beyond the limit too.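

Compound 3 and compound 4 both give only a limit, not a number, so no step between them can be read: the limit of > 30000 nM in this assay, at which 4 of the 4 values shown sit.

The compounds shown leave open whether any change to the shared core would give a measurable value in this assay.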